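Methyl to Cyano Across a Mer Kinase Inhibitor Pair

This account rests on a few compounds, and the source may have more. Where it says the series, first, only, none or still open, it means among the compounds named here.

Of the compounds shown here, three have been tested in an assay on isolated protein for inhibition of tyrosine-protein kinase Mer (Homo sapiens), read by LC-MS; on this read-out lower numbers stand for stronger inhibition and higher numbers for weaker inhibition. Compound 1 `CN(Cc1ccc2nccn2c1)c1nnc(-c2ccc(-c3ccccc3C#N)cc2)o1` gives 25.1 nM in this assay. Compound 2 `Cc1ccccc1-c1ccc(-c2nnc(N(C)Cc3ccc4nccn4c3)o2)cc1` gives 12.6 nM in this assay. Compound 3 `Cc1cc(-c2c(C)nn(C)c2C)ccc1-c1nnc(N(C)Cc2ccc3nccn3c2)o1` gives 3.16 nM in this assay, the lowest of the three. How the core of compound 3 differs from that of compound 2 is not broken down here. From compound 2 to compound 1 the change is cyano in place of methyl on an aromatic carbon, and it made a 2.0-fold higher number from compound 2 to compound 1 (0.30 log units; within the scatter).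

Compound 4 `Cc1nn(C)c(C)c1-c1ccc(-c2nnc(N(C)Cc3ccc4nccn4c3)o2)c(C#N)c1` has not yet been measured in this assay. It differs from compound 3 by cyano in place of methyl on an aromatic carbon. The surroundings are not identical: in compound 4 the aromatic carbon is also meta to a 1,3,5-trimethyl-1H-pyrazol-4-yl group, so this is the same kind of change rather than the same change. A step of about a 2.0-fold higher number from compound 3 to compound 4 (0.30 log units; within the scatter) is expected, because the same kind of change made a 2.0-fold higher number from compound 2 to compound 1 (0.30 log units; within the scatter). Compound 4 is therefore estimated at 6.3 nM, with a likely range from 2.5 nM to 16 nM.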

Compound 4, half-maximal inhibitory concentration: 100000 nM
Beside the measured number, compound 4's estimate is 16000-fold (4.20 log units) below it, outside the stated range (above it).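

In this assay, cyano in place of methyl on an aromatic carbon gave a 32000-fold higher number from compound 3 to compound 4 (4.50 log units; beyond the scatter), a step that here sits on a carbon ortho to a large group and meta to a 1,3,5-trimethyl-1H-pyrazol-4-yl group. The size of this change therefore did not carry from one core to the other in this series, as the two steps show: the same change on two cores in this assay, a 2.0-fold higher number (0.30 log units; within the scatter) from compound 2 to compound 1 and a 32000-fold higher number (4.50 log units; beyond the scatter) from compound 3 to compound 4, 16000-fold (4.20 log units) apart, beyond the scatter of two such steps This does not show which difference between the cores accounts for the gap, and two pairs give no rule for how the change would behave on any further core.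

The compounds shown leave open whether a methoxy group or an amine on that aromatic carbon would stay close to compound 3 at 3.16 nM or would move as far as the cyano did. They also leave open how the methyl-to-cyano step would run with a carboxylic acid or a longer chain in place of the 1,3,5-trimethyl-1H-pyrazol-4-yl group.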